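From methoxy to hydroxy in an antiproliferative series

A few compounds are considered here, and "the series" means these few. Any claim that something is new, unique, unknown or untested is made for them only; others in the source may bear on it.

Of the compounds shown here, three built on a shared core have been tested in a functional assay on MDA-MB-231 cells (Homo sapiens) for antiproliferative activity, read by sulforhodamine B assay, with a stated time of 72 h; on this read-out higher numbers stand for weaker inhibition and lower numbers for stronger inhibition. Going by the values given here, compound 3 `COc1cc2occ(-c3csc4ccccc34)c(=O)c2c(OC)c1OC` gives 820 nM, the only true number among them. Compound 1 `COc1c(OC(C)C)cc2occ(-c3csc4ccccc34)c(=O)c2c1OC(C)C` gives > 10000 nM, which is a limit of the assay. Compound 2 `COc1c(O)cc2occ(-c3csc4ccccc34)c(=O)c2c1O` gives > 10000 nM, which is also a limit of the assay. Among the compounds with values here, compound 3 therefore stands alone as the one compound with a measured potency, and it provides the only numerical reference point in the set.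

Compound 4 `COc1cc2occ(-c3csc4ccccc34)c(=O)c2c(OC)c1O` departs from compound 3 by a single change: hydrogen in place of methyl on an oxygen on an aromatic ring. Put simply, this is methoxy to hydroxy, with hydrogen in place of methyl on an oxygen on an aromatic ring. Within the data shown here, no measured pair isolates this change, so the size of its effect in this assay has to be judged indirectly. Weaker inhibition is expected, by a step beyond the usual scatter. The expectation rests on compound 2, which also carries hydroxy groups and reads > 10000 nM, a limit. The estimated move is a 3.7-fold higher number from compound 3 to compound 4 (0.56 log units; beyond the scatter). For compound 4 the expected value is 3000 nM, with an estimated range of 800 nM to 10000 nM.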

Compound 4, half-maximal inhibitory concentration: > 10000 nM
Compound 4 gave a limit, no number; the forecaster's own chance of this, stated with the estimate: 30%; middle value at least 3.3-fold (0.52 log units) away from the limit.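

Compound 1 and compound 2 both keep the methoxy at this place and differ from compound 3 at the other two oxygens, so neither could show what this oxygen contributes. Going by these compounds alone, the single change now isolates it in this assay: hydrogen in place of methyl on an oxygen on an aromatic ring gives an at least 12-fold higher number from compound 3 to compound 4 (1.08 log units; beyond the scatter). Methoxy to hydroxy at this one place is thus enough on its own to take compound 3, the only compound with a true number, to the limit of the read-out, and the step can be stated only as a minimum because the read-out ends there: the limit of > 10000 nM in this assay, at which 3 of the 4 values shown sit.

The compounds shown do not tell whether the loss follows from removing the methyl or from the new hydroxy, and a longer chain such as ethoxy, or an amine at the same place, would be needed to tell these apart. How compound 3 responds to a single change at either of the other two oxygens also remains open, since no compound shown changes one of them alone.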